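A few compounds are considered here, and "the series" means these few. Any claim that something is new, unique, unknown or untested is made for them only; others in the source may bear on it.

Compound 3 `CC(C)(C)Cc1c(-c2ccc(OC(F)(F)F)cc2)sc(N)c1C(=O)c1ccc(Cl)cc1` shares its core with compound 1 `CC(C)(C)Cc1c(-c2ccc(F)cc2)sc(N)c1C(=O)c1ccc(Cl)cc1` and compound 2 `CC(C)(C)Cc1c(-c2ccc(Cl)c(Cl)c2)sc(N)c1C(=O)c1ccc(Cl)cc1`. In an assay on CHO cells for displacement of a labelled ligand from adenosine receptor A1 (Homo sapiens), read by scintillation counting, tested at 10 uM (a lower number here means less inhibition, a higher number more inhibition at the concentration tested (going by the name of the read-out)), compound 1 gives 1%, compound 2 gives 1%, and compound 3 gives 1%, so compound 3 stands level with both. The steps of no change at the digits printed from compound 1 to compound 2 (within the scatter) and no change at the digits printed from compound 1 to compound 3 (within the scatter) show that exchanging the group on an aromatic carbon left this assay unmoved. Compound 4 `Cc1ccc(-c2sc(N)c(C(=O)c3ccc(Cl)cc3)c2CC(C)(C)C)cc1` differs from compound 3 by methyl in place of trifluoromethoxy on an aromatic carbon. This is an exchange of the same kind at the same place, so both measured steps bear on it, and both stayed within the scatter. Compound 4 is therefore expected to show no change at the digits printed from compound 3 to compound 4 (within the scatter) in this assay, that is, no change beyond the scatter. The estimate for compound 4 is 1%, with a range from 0% to 10%.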

Compound 4, a percentage reported as inhibition, at one concentration (the size of the read-out at that concentration, not a potency): 1%
For compound 4 middle estimate and measured number coincide at the digits printed; measured number inside the range.
By their numbers in this assay, from the lowest: compounds 1, 2, 3 and 4 (each within the scatter of the next).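

Methyl, which carries no fluorine or oxygen, in place of trifluoromethoxy on this aromatic carbon, para to a large group, gives no change at the digits printed from compound 3 to compound 4 (within the scatter) in this assay, so the flat result now extends to a plain carbon group. Going by these compounds alone, compound 4 also matches the earlier compounds, with no change at the digits printed from compound 2 to compound 4 (within the scatter) and no change at the digits printed from compound 1 to compound 4 (within the scatter) in the same assay. Nothing measured here explains this lack of response.
On these data alone, whether an amine or a carboxylic acid on this carbon would raise the inhibition stays open. So does the effect of changes elsewhere on the shared core.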